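Chloro in place of methoxy on the aromatic ring

This account rests on a few compounds, and the source may have more. Where it says the series, first, only, none or still open, it means among the compounds named here.

Compound 1 `COc1ccc(/C=N/NC(=S)NC(C)(C)[C@H]2CC=C(C)CC2)cc1` carries a methoxy on its aromatic ring; in a functional assay on K562 cells (Homo sapiens) for inhibition, read by sulforhodamine B assay, with a stated time of 48 h (a higher number here means a weaker inhibitor of growth, a lower number a stronger inhibitor of growth), compound 1 gives 1500 nM. Among the numbers shown it holds the lowest one. Compound 3 `CC1=CC[C@H](C(C)(C)NC(=S)N/N=C/c2ccc(N(C)C)cc2)CC1` bears dimethylamino in place of that methoxy, and in this assay compound 3 gives 22600 nM, so that a 15-fold higher number from compound 1 to compound 3 (1.18 log units; beyond the scatter). Compound 2 `CC1=CC[C@H](C(C)(C)NC(=S)N/N=C/c2ccc(O)cc2)CC1` carries hydroxy at the same place. In this assay compound 2 reaches only a limit of the assay, > 100000 nM, which is the limit of > 100000 nM in this assay, at which 1 of the 3 values shown sits. Hence an at least 66-fold higher number from compound 1 to compound 2 (1.82 log units; beyond the scatter). Between those two, an at least 4.4-fold lower number from compound 2 to compound 3 (0.64 log units; beyond the scatter).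

Compound 4 `CC1=CC[C@H](C(C)(C)NC(=S)N/N=C/c2ccc(Cl)cc2)CC1` is not yet measured. Its change from compound 1 is chloro in place of methoxy on an aromatic carbon. Among the measured compounds shown here, no measured step exchanges methoxy for chloro, so the two steps away from compound 1 are the only guide: both remove the methoxy and both lead to a weaker inhibitor of growth, one of them beyond the range of the assay. Whether chloro follows the same direction cannot be read from hydroxy and dimethylamino, and the expectation is therefore a modest rise, the step from compound 1 to compound 4 being estimated as a 2.3-fold higher number from compound 1 to compound 4 (0.37 log units; beyond the scatter), with a wide range. Compound 4 is expected to give about 3500 nM, between 800 nM and 25000 nM.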

Compound 4, concentration for 50% growth inhibition: 300 nM
Compound 4: the middle estimate sits 12-fold (1.07 log units) above what was measured, and the stated range ends above it.
By their numbers in this assay, from the lowest: compound 4; then compound 1; then compound 3. At a limit, above all of these: compound 2.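

The exchange of methoxy at this place, on an aromatic carbon para to a large group, need not weaken growth inhibition in this assay: chloro in place of methoxy lowers the number (a 5.0-fold lower number from compound 1 to compound 4 (0.70 log units; beyond the scatter)), the opposite direction to hydroxy and dimethylamino. Among the groups at this place, chloro now marks the low end of the series, well separated from dimethylamino (a 75-fold lower number from compound 3 to compound 4 (1.88 log units; beyond the scatter)) and from hydroxy (an at least 330-fold lower number from compound 2 to compound 4 (2.52 log units; beyond the scatter)), so a single substituent on the aromatic ring spans a wide range of numbers and methoxy no longer gives the lowest one. Compound 2 remains at a limit of the assay, so its step to chloro is a bound and not a measured size: the limit of > 100000 nM in this assay, at which 1 of the 4 values shown sits.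

As far as these compounds go, whether the lower number is particular to chloro or extends to bromo, fluoro, trifluoromethyl or a nitrile at this place remains open. Also open, from the compounds shown here alone, is whether chloro keeps this number at another place on the aromatic ring, and how it behaves with a different group, such as a longer chain, on the rest of the shared core.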